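From Ethyl to Phenyl: Expecting the Next Measurement

This account rests on a few compounds, and the source may have more. Where it says the series, first, only, none or still open, it means among the compounds named here.

Measured so far in a functional assay for inhibition of sodium/hydrogen exchanger (Oryctolagus cuniculus); a lower number here means a stronger inhibitor, a higher number a weaker inhibitor:
compound 1 `Cc1c(C(=O)N=C(N)N)cc(S(C)(=O)=O)c(Cl)c1[N+](=O)[O-]` gives 44 nM
compound 2 `CCc1cc(C)c(C(=O)N=C(N)N)cc1S(C)(=O)=O` gives 4.8 nM
compound 3 `Cc1c(C(=O)N=C(N)N)cc(S(C)(=O)=O)c(C)c1C` gives 55 nM

Among these three, compound 2 has the lowest number in this assay. Its nearest neighbour is compound 1, whose number is higher by a margin beyond the scatter, and compound 3 lies further still, also beyond the scatter. Compound 2 is therefore the strongest inhibitor of the three shown.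

Compound 4 `Cc1cc(-c2ccccc2)c(S(C)(=O)=O)cc1C(=O)N=C(N)N` has not yet been measured. It differs from compound 2 in one place: phenyl in place of ethyl on an aromatic carbon. Going by the values given here, no pair of measured compounds differs in this one place alone, so nothing measured here tells directly how such a change moves the number.

With no direct comparison available, the expectation rests only on compound 2 and the size of the group entering. The step expected here is a 3.1-fold higher number from compound 2 to compound 4 (0.49 log units; beyond the scatter), a modest weakening that is not certain to exceed the scatter. Compound 4 is accordingly estimated at 15 nM in this assay, within a range from 4 nM to 60 nM.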

Compound 4, half-maximal inhibitory concentration: 19 nM
Estimate against measurement, compound 4: 1.3-fold (0.10 log units) below, and the stated range covers the measured number.
By their numbers in this assay, from the lowest: compound 2; then compound 4; then compounds 1 and 3 (each within the scatter of the next).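

Going by these compounds alone, the step gives the first direct reading at this position, an aromatic carbon ortho to a methylsulfonyl group and meta to a methyl group: in this assay, phenyl in place of ethyl brings a 4.0-fold higher number from compound 2 to compound 4 (0.60 log units; beyond the scatter), a modest weakening. The position therefore tolerates a much larger group, a six-membered aromatic ring of carbon only with 6 heavy atoms in place of 2, and compound 4 still gives 19 nM, so the change costs some inhibition without abolishing it. Nothing available explains why the number rises with this change.

As far as these compounds go, a single step cannot separate the effect of the added atoms from that of the ring itself, so it remains open whether a longer chain such as propyl, a saturated ring such as cyclohexyl, or a phenyl carrying an amine or a carboxylic acid would fall closer to compound 2 or to compound 4. From the compounds shown here alone, it also remains open whether phenyl in place of ethyl would move the number by a similar amount if other groups on the shared core were changed.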